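This account rests on a few compounds, and the source may have more. Where it says the series, first, only, none or still open, it means among the compounds named here.

Measured so far:
- compound 1, `C=C=CCC[C@@H]1C(=O)OC[C@H]2C(=C)CC[C@@H]3O[C@@]3(C)CC[C@H]12`: 1.6 ug/mL
- compound 2, `C=C=CC/C=C1/C(=O)OC[C@H]2C(=C)CC[C@@H]3O[C@@]3(C)CC[C@H]12`: 52 ug/mL

In a functional assay on K562 cells (Homo sapiens) for cytotoxicity (on this read-out lower numbers stand for higher toxicity in this test and higher numbers for lower toxicity in this test), compound 1 gives 1.6 ug/mL, the lowest of the two numbers in hand. Compound 2, in the same assay, gives 52 ug/mL, a number well beyond the scatter from that of compound 1; the two differ in more than one place, so only their two values can be set side by side.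

Compound 3, `C=C1CC[C@@H]2O[C@@]2(C)CC[C@@H]2[C@H](CCC=C(C)C)C(=O)OC[C@@H]12`, has not yet been measured. It differs from compound 1 in one place: 2-methylprop-1-en-1-yl in place of propa-1,2-dien-1-yl on a saturated chain carbon, two bonds along the chain from a saturated ring carbon. Going by the values given here, no measured pair shows this exact change, so the size of the step is open. With only one listed neighbour, a moderate step is expected, in the direction of a somewhat higher number, with a fair chance that it remains within the scatter. The expected step is a 2.2-fold higher number from compound 1 to compound 3 (0.34 log units; beyond the scatter). Compound 3 is thus estimated at 3.5 ug/mL, in the range from 1 ug/mL to 12 ug/mL.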

Compound 3, concentration lethal to 50% of the cells: 0.2 ug/mL
Compound 3: the middle estimate sits 18-fold (1.24 log units) above what was measured, outside the stated range (below it).
By their numbers in this assay, from the lowest: compound 3; then compound 1; then compound 2.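

In this assay, putting 2-methylprop-1-en-1-yl in place of propa-1,2-dien-1-yl on a saturated chain carbon, two bonds along the chain from a saturated ring carbon, gives an 8.0-fold lower number from compound 1 to compound 3 (0.90 log units; beyond the scatter) and so moves the read-out towards higher toxicity in this test. This shows that the read-out responds to the end of this chain, even when the core of compound 1 stays unchanged. Nothing at hand accounts for the size or direction of this step.

Going by these compounds, this reading rests on a single pair, so it remains open whether the step follows from the methyl branching or from the loss of one double bond. Also open, on these data alone, is how a saturated butyl chain or a terminal amine would read at this place, and whether the same change would give a like step on compound 2.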